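This account rests on a few compounds, and the source may have more. Where it says the series, first, only, none or still open, it means among the compounds named here.

In a functional assay on Jurkat cells (Homo sapiens) (a lower number here means a stronger inhibitor, a higher number a weaker inhibitor), compound 1 `CC(C)[C@H](NC(=O)COc1cccc2ccccc12)C(=O)N[C@@H](CC(=O)O)C(=O)COc1ccccc1C(F)(F)F` gives > 100000 nM, which is a limit of the assay and not a number. Compound 2 `CC(C)[C@H](NC(=O)COc1cccc2ccccc12)C(=O)N[C@@H](CC(=O)O)C(=O)COc1ccc(Oc2ccccc2)cc1` gives 12700 nM, and compound 3 `CC(C)[C@H](NC(=O)COc1cccc2ccccc12)C(=O)N[C@@H](CC(=O)O)C(=O)COc1ccc(OC(F)(F)F)cc1` gives 29100 nM, the higher of the two actual numbers. Compound 4 `CC(C)[C@H](NC(=O)COc1cccc2ccccc12)C(=O)N[C@@H](CC(=O)O)C(=O)COc1ccc([N+](=O)[O-])cc1` has not yet been measured. It departs from compound 3 in one place: nitro in place of trifluoromethoxy on an aromatic carbon.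

The closest guide is a 2.3-fold higher number from compound 2 to compound 3 (0.36 log units; beyond the scatter), a modest step from a change of group at this same place. A second guide, an at least 3.4-fold lower number from compound 1 to compound 3 (0.53 log units; beyond the scatter), is at least modest, but it rests on a limit and replaces the whole substituted phenyl. Neither step shows how nitro itself will behave, so no direction is firmly indicated. Because the closest guide is only a 2.3-fold higher number from compound 2 to compound 3 (0.36 log units; beyond the scatter) in size, no step beyond the scatter is expected in this assay. The expected step is a 1.1-fold higher number from compound 3 to compound 4 (0.04 log units; within the scatter). Compound 4 is estimated at 32000 nM, with an expected range from 12000 nM to 90000 nM.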

Compound 4, half-maximal inhibitory concentration: > 100000 nM
Compound 4: only a limit was reported; the forecaster's own chance of this, stated with the estimate: 12%; middle value at least 3.1-fold (0.49 log units) away from the limit.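

In this assay compound 4 gives > 100000 nM, which is a limit of the assay and not a number. At this aromatic carbon, para to a large group, nitro in place of trifluoromethoxy gives an at least 3.4-fold higher number from compound 3 to compound 4 (0.53 log units; beyond the scatter), and nitro in place of phenoxy gives an at least 7.8-fold higher number from compound 2 to compound 4 (0.89 log units; beyond the scatter), so the group here can shift the number further than the earlier modest step at this place had shown. Reaching the limit is also no longer confined to the 2-(trifluoromethyl)phenyl of compound 1, since a group at this other place reaches it too: the limit of > 100000 nM in this assay, at which 2 of the 4 values shown sit.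

Going by these compounds, the step between compound 1 and compound 4 cannot be read, and how far compound 4 lies past its limit stays unknown. The compounds shown also leave open how an amine or a carboxylic acid on this same aromatic carbon would behave.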